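The source may hold more compounds than are shown below. What is called first, only, known or untested is meant among the compounds shown, and "the series" means these compounds.

Within the data shown here, in a functional assay on HT-29 cells (Homo sapiens) for inhibition, read by luminescence and CellTiter-Glo, with a stated time of 10 h (on this read-out higher numbers stand for an effect only at larger amounts of compound and lower numbers for an effect already at smaller amounts), compound 2 `O=C(N[C@H]1COc2ccccc2NC1=S)c1n[nH]c(Cc2ccccc2)n1` reads 736 nM as its only number, with one further entry that carries no single number. Compound 1 `CN1C(=S)[C@@H](NC(=O)c2n[nH]c(Cc3ccccc3)n2)COc2ccccc21` gives 2.8 nM; 7.4 nM (2 entries) in this assay and both of its entries are far lower than the number of compound 2.

Compound 3 `CCN1C(=S)[C@@H](NC(=O)c2n[nH]c(Cc3ccccc3)n2)COc2ccccc21` has not yet been measured. The change from compound 2 is ethyl in place of hydrogen on an amide-type nitrogen in a ring and puts ethyl in place of hydrogen on an amide-type nitrogen in a ring. Among the measured compounds shown here, no measured step shows this change directly, so any expectation rests on the two sets of values alone. Compound 1 at 2.8 nM; 7.4 nM (2 entries) shows that numbers far lower than that of compound 2 occur in the series, and a large downward move beyond the scatter is expected in this assay for this change, though probably not all the way to the values of compound 1. The expected step is a 29-fold lower number from compound 2 to compound 3 (1.47 log units; beyond the scatter) on this estimate. Compound 3 is estimated at 25 nM with 5 nM to 130 nM as the expected range.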

Compound 3, half-maximal effective concentration: 1510 nM
The estimate for compound 3 lay 60-fold (1.78 log units) below the measured number; measured number above the stated range.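

At the amide-type nitrogen in a ring, putting a group in place of hydrogen does not by itself lower the number in this assay: ethyl gives a 2.1-fold higher number from compound 2 to compound 3 (0.31 log units; beyond the scatter), a modest step that runs opposite to the low numbers seen with methyl at this position. The outcome therefore depends on which group enters and not merely on whether one does, as compound 1, with methyl, gives 2.8 nM; 7.4 nM (2 entries), whereas compound 3, with ethyl, gives 1510 nM. The low numbers of the methyl compound do not rest on a single entry, since both lie far lower than the numbers of compound 2 and compound 3: the several entries of compound 1 in this assay, 2.8 nM; 7.4 nM (2 entries).

The compounds shown do not explain why methyl and ethyl part so sharply here, and they do not show whether a propyl chain, a cyclopropyl ring or a longer chain ending in an amine or a carboxylic acid would continue the ethyl trend or depart from it. On these data alone, whether the same preference for methyl holds when the benzyl group or the fused benzene ring of the shared core carries a further substituent also remains open.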